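A 4-chlorophenyl replaces the aroyl group of compound 2

The compounds below may be only part of what the source reports. "The series", "measured", "known", "first", "only" and "open" are said of these compounds alone.

Compound 1 `COc1ccc2c(=O)c(-c3cc(OC)c(OC)cc3OC)coc2c1` gives in a functional assay on HCT-116 cells (Homo sapiens) for antiproliferative activity, read by MTT assay, with a stated time of 24 h (a higher number here means a weaker inhibitor, a lower number a stronger inhibitor), a value of 9170 nM. Compound 3 `COc1cc(OC)c(-c2coc3cc(OCc4ccc(C#N)cc4)ccc3c2=O)cc1OC` gives 4220 nM in this assay. Compound 2 `COc1cc(OC)c(-c2coc3cc(OCC(=O)c4cccc(C(F)(F)F)c4)ccc3c2=O)cc1OC` reaches only the limit of this assay, > 10000 nM, so for compound 2 no number is known, only that limit (the limit of > 10000 nM in this assay, at which 1 of the 3 values shown sits). Compound 4 `COc1cc(OC)c(-c2coc3cc(OCc4ccc(Cl)cc4)ccc3c2=O)cc1OC` has not yet been measured; it differs from compound 2 by 4-chlorophenyl in place of (3-(trifluoromethyl)phenyl)carbonyl on a saturated chain carbon bound to an oxygen on an aromatic ring. The measured step that bears most directly on it is an at least 2.3-fold lower number from compound 2 to compound 3 (0.37 log units; beyond the scatter), where the same group leaves and a 4-cyanophenyl enters. Compound 3 stands against the parent as a 2.2-fold lower number from compound 1 to compound 3 (0.34 log units; beyond the scatter), while compound 2 stands as an at least 1.0-fold higher number from compound 1 to compound 2 (0.03 log units; that floor lies within the scatter). Because an at least 2.3-fold lower number from compound 2 to compound 3 (0.37 log units; beyond the scatter) was measured with the same group leaving and compound 4 carries a 4-chlorophenyl where compound 3 carries a 4-cyanophenyl, the expected step is an at least 2.2-fold lower number from compound 2 to compound 4 (0.34 log units; beyond the scatter), a modest fall from the limit. Compound 4 is therefore estimated at 4500 nM in this assay, within a range of 2000 nM to 10000 nM.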

Compound 4, half-maximal inhibitory concentration: 4450 nM
Estimate against measurement, compound 4: 1.0-fold (0.00 log units) above; the measured number falls inside the stated range.
By their numbers in this assay, from the lowest: compounds 3 and 4 (each within the scatter of the next); then compound 1. At a limit, above all of these: compound 2.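

In this assay, chloro in place of cyano on an aromatic carbon gives a 1.1-fold higher number from compound 3 to compound 4 (0.02 log units; within the scatter) and the 4-chlorophenyl group stands against the parent as a 2.1-fold lower number from compound 1 to compound 4 (0.31 log units; beyond the scatter) in its own right, so the shift seen with compound 3 is not confined to a 4-cyanophenyl group. The exchange of the aroyl group now reads as an at least 2.2-fold lower number from compound 2 to compound 4 (0.35 log units; beyond the scatter) with a second substituted phenyl group, and this is a floor for the size of that step. Compound 2 gives a limit and not a number: the limit of > 10000 nM in this assay, at which 1 of the 4 values shown sits.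

The compounds shown leave open how a 4-aminophenyl or 4-carboxyphenyl group on the same saturated chain carbon would stand. They also do not separate the carbonyl of compound 2 from its trifluoromethyl group, and a plain 3-(trifluoromethyl)phenyl group would bear on that.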